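The source may hold more compounds than are shown below. What is called first, only, known or untested is meant among the compounds shown, and "the series" means these compounds.

Measured compounds:
compound 1, `CC(C)C(C)(C)/N=C(\NC#N)Nc1ccncc1`, 20 mg/kg
compound 2, `CC(C)(C)C(C)(C)/N=C(\NC#N)Nc1ccncc1`, 20 mg/kg
compound 3, `N#CN/C(=N\Cc1ccccc1)Nc1ccncc1`, 5 mg/kg

All three were tested in a functional assay on the whole organism (blood, strain Wistar-Okamoto) with Rattus norvegicus as the target, with a stated time of 5 days; on this read-out lower numbers stand for an effect already at smaller amounts and higher numbers for an effect only at larger amounts of compound. Compound 1 and compound 2 share a core and differ only in methyl in place of hydrogen on a saturated chain carbon bound to three saturated chain carbons; this gave no change at the digits printed from compound 1 to compound 2 (within the scatter). Compound 3 has the lowest number of the three, and the difference between its core and the core of compound 1 is not broken down here.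

Compound 4, `CC(/N=C(\NC#N)Nc1ccncc1)c1ccccc1`, has not yet been measured. It differs from compound 3 in methyl in place of hydrogen on a saturated chain carbon bound to an aromatic carbon and a double-bonded nitrogen. This is the same kind of change as from compound 1 to compound 2, but the place is not the same: there the carbon was bound to three saturated chain carbons, here it is bound to an aromatic carbon and a double-bonded nitrogen. Among the compounds with values here, the only measured example of this kind of change left the number unchanged, so a similar outcome is expected, with no change at the digits printed from compound 3 to compound 4 (within the scatter) as the estimated step beside the earlier one, resting on no change at the digits printed from compound 1 to compound 2 (within the scatter). Compound 4 is therefore expected to give about 5 mg/kg in this assay, estimated within 2 mg/kg to 15 mg/kg.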

Compound 4, minimum effective dose: 10 mg/kg
For compound 4 the middle estimate is 2.0-fold (0.30 log units) below the measured one; the range from low to high includes it.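

In this assay, putting methyl in place of hydrogen on a saturated chain carbon bound to an aromatic carbon and a double-bonded nitrogen gave a 2.0-fold higher number from compound 3 to compound 4 (0.30 log units; within the scatter). Set beside the earlier example, the change carries from one core to the other with no difference that can be told apart from the scatter: the same change on two cores in this assay, no change at the digits printed (within the scatter) from compound 1 to compound 2 and a 2.0-fold higher number (0.30 log units; within the scatter) from compound 3 to compound 4, 2.0-fold (0.30 log units) apart, within the scatter of two such steps. This shows only that, in these two pairs, adding a methyl left no effect that this read-out can separate from the scatter; it does not show that the same would hold on other cores or at other places, and it gives no reason for the result.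

The compounds shown leave open whether a longer chain, an amine or a carboxylic acid in place of that hydrogen would also leave the number within the scatter. As far as these compounds go, an ethyl group would be the smallest step beyond methyl, and its outcome remains open here.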